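Tert-butyl for ethyl on the amine of compound 1

This account rests on a few compounds, and the source may have more. Where it says the series, first, only, none or still open, it means among the compounds named here.

Measured in an ADME assay on microsomes from liver (Mus musculus) for metabolic stability, read by LC-MS, with a stated time of 30 min, tested at 1 uM; a higher number here means that more of the compound is left, a lower number that less of the compound is left:
compound 1 `CCNCc1cc(C)cc(Nc2nc3ccccc3n2Cc2ccc(C(F)(F)F)cc2)c1O`: 52%
compound 2 `CCNCc1cc(Cl)cc(Nc2nc3ccccc3n2Cc2ccc(C(F)(F)F)cc2)c1O`: 73%
compound 3 `CCNCc1cc(Cl)cc(Nc2nc3cc(F)c(F)cc3n2Cc2ccc(C(F)(F)F)cc2)c1O`: 86%
Not yet measured: compound 4 `Cc1cc(CNC(C)(C)C)c(O)c(Nc2nc3ccccc3n2Cc2ccc(C(F)(F)F)cc2)c1`

Compound 1, at 52%, has the lowest number of the three in this assay, and both other compounds lie beyond the scatter from it. Compound 4 keeps the core of compound 1 and differs only at the amine: tert-butyl in place of ethyl on an amine nitrogen. This is tert-butyl in place of ethyl on an amine nitrogen.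

Within the data shown here, no measured pair changes the group on that nitrogen, so the data offer no direct precedent and no firm direction. Among the measured compounds shown here, the only measured step between compounds that differ in one place is a number 21 percentage points higher from compound 1 to compound 2 (beyond the scatter), and it comes from chloro in place of methyl on an aromatic carbon. That step serves only as a yardstick of size for this series, and it says nothing specific about the amine.

A small rise is expected, smaller than that yardstick, with a real chance of no change beyond the scatter. The expected step is a number 10 percentage points higher from compound 1 to compound 4 (within the scatter). For compound 4 the estimate is 62%, with an expected range of 42% to 82%.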

Compound 4, percent of the compound remaining in the Mus musculus assay: 62%
Compound 4: the middle estimate sits on the measured number at the digits printed; low and high end bracket the measured number.
By their numbers in the Mus musculus assay, from the lowest: compounds 1 and 4 (each within the scatter of the next); then compound 2; then compound 3.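

In the Mus musculus assay compound 1 gives 52% and compound 4 gives 62% with tert-butyl in place of ethyl on an amine nitrogen, which is a number 10 percentage points higher from compound 1 to compound 4 (within the scatter) and so leaves stability on the core of compound 1 unresolved from the ethyl case, while the aromatic carbon has given a step beyond the scatter (a number 21 percentage points higher from compound 1 to compound 2 (beyond the scatter)). Among these compounds, this is the first read on the amine position, and on these two compounds the tert-butyl group is accommodated there without a step that can be told from the scatter. In a physicochemical assay for solubility, read by HPLC, measured as kinetic solubility, with a stated time of 24 h, at pH 6.5 (on this read-out lower numbers stand for lower solubility and higher numbers for higher solubility), compound 1 gives 35000 nM and compound 4 gives 50000 nM with the same change, which is a 1.4-fold higher number from compound 1 to compound 4 (0.15 log units; within the scatter) and again stays inside the scatter, so neither read-out separates the two groups on this nitrogen, and nothing at hand explains the outcome at this position.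

From the compounds shown here alone, whether tert-butyl on the amine nitrogen gives a similar result on the chloro core of compound 2 or the core of compound 3 remains open. Also open, going by these compounds, is what a cyclopropyl or 2-hydroxyethyl group on that nitrogen would give in the Mus musculus assay and in the physicochemical assay on the core of compound 1.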